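The source may hold more compounds than are shown below. What is called first, only, known or untested is meant among the compounds shown, and "the series" means these compounds.

Three compounds built on one shared core were measured in a physicochemical assay for solubility, at pH 7; on this read-out higher numbers stand for higher solubility and lower numbers for lower solubility. Compound 1 `CN1CCC(C(=O)N2Cc3c(NC(=O)C4CCC4)n[nH]c3C2(C)C)CC1` carries cyclobutyl on the carbonyl carbon, and in this assay compound 1 gives > 225000 nM, which is a limit of the assay and not a number. Compound 2 `CN1CCC(C(=O)N2Cc3c(NC(=O)c4ccsc4)n[nH]c3C2(C)C)CC1` carries thiophen-3-yl in that place, and in this assay compound 2 gives the limit > 225000 nM. Compound 3 `CN1CCC(C(=O)N2Cc3c(NC(=O)c4ccco4)n[nH]c3C2(C)C)CC1` carries furan-2-yl, and in this assay compound 3 gives only the limit > 225000 nM. The steps a step that the two limits leave unreadable from compound 1 to compound 2, a step that the two limits leave unreadable from compound 1 to compound 3 and a step that the two limits leave unreadable from compound 2 to compound 3 cannot be read because of the limit of > 225000 nM in this assay, at which 3 of the 3 values shown sit. Compound 3 thus stands at the limit together with the other two.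

Compound 4 `CCCNC(=O)Nc1n[nH]c2c1CN(C(=O)C1CCN(C)CC1)C2(C)C` has not yet been measured. It differs from compound 3 in one place: propylamino in place of furan-2-yl on a carbonyl carbon. Going by the values given here, no measured step bears on this change with a readable size, so no direction can be drawn from them. The author expects the step that the limit leaves unreadable from compound 3 to compound 4 to stay within the scatter, with compound 4 most likely reaching the limit again. For compound 4 the estimate in this assay is 250000 nM, with a range from 80000 nM to 600000 nM.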

Compound 4, solubility: > 225000 nM
Compound 4 ended at the assay's limit (the forecaster's own chance of this, stated with the estimate: 80%); the middle value is on the limit's open side.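

In this assay compound 4 gives > 225000 nM, a limit and not a number. Its steps to compound 1, compound 2 and compound 3 cannot be read: the limit of > 225000 nM in this assay, at which 4 of the 4 values shown sit.

The compounds shown leave open how far any of the four lies past that limit, and so whether cyclobutyl, thiophen-3-yl, furan-2-yl and propylamino differ at all in this assay.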